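The source may report more compounds than this note shows. Statements on the series, on what has been measured and on what is new or still open speak of the compounds shown alone.

Measured compounds:
- compound 1, `COc1cc(Cl)cc(-c2nn(-c3cccc(NC(=O)c4ccc(Cl)c(Cl)c4)c3)cc2-c2ccncc2)c1`: 56.4%
- compound 2, `O=C(Nc1cccc(-n2cc(-c3ccncc3)c(-c3cc(O)cc(Cl)c3)n2)c1)Nc1ccc(Cl)c(C(F)(F)F)c1`: 35.3%
- compound 3, `COc1cc(Cl)cc(-c2nn(-c3cccc(NC(=O)Nc4ccc(Cl)c(C(F)(F)F)c4)c3)cc2-c2ccncc2)c1`: 5.57%

In a functional assay on HT-29 cells (Homo sapiens) for inhibition, read by sulforhodamine B assay, with a stated time of 48 h, tested at 10 uM (on this read-out lower numbers stand for a stronger effect and higher numbers for a weaker effect at the one concentration tested), compound 3 stands lowest of the three, with compound 2 nearest at 35.3% and compound 1 furthest at 56.4%, both steps beyond the scatter. Compound 4, `COc1cc(Cl)cc(-c2nn(-c3cccc(NC(=O)Nc4ccc(Cl)c(Cl)c4)c3)cc2-c2ccncc2)c1`, is not yet measured. It differs from compound 3 by chloro in place of trifluoromethyl on an aromatic carbon.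

Neither measured step isolates this change. The step of a number 50.8 percentage points lower from compound 1 to compound 3 (beyond the scatter) changes the urea against the amide and the aryl substitution at once. The aryl change on its own cannot be read from it. The step of a number 29.7 percentage points lower from compound 2 to compound 3 (beyond the scatter) concerns the methyl on the oxygen and does not bear on the urea aryl. Compound 1 carries the 3,4-dichlorophenyl, but on a carbonyl carbon without the amino, so its value gives only a loose reference. A step in this assay from compound 3 to compound 4 is therefore expected to be small, tending upward, and it may well stay within the scatter.

Compound 4 is estimated at 15%, ranging from 3% to 40%. The expected step is a number 9.4 percentage points higher from compound 3 to compound 4 (within the scatter).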

Compound 4, a percentage reported as activity, at one concentration (the size of the read-out at that concentration, not a potency): 7.39%
Estimate against measurement, compound 4: 7.6 percentage points above; the range from low to high includes it.
By their numbers in this assay, from the lowest: compounds 3 and 4 (each within the scatter of the next); then compound 2; then compound 1.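

In this assay, the step of a number 1.8 percentage points higher from compound 3 to compound 4 (within the scatter) shows that on this aromatic carbon, ortho to a chloro group, chloro in place of trifluoromethyl leaves the read-out within the scatter, so the low number of compound 3 does not depend on the trifluoromethyl. With the 3,4-dichlorophenyl held constant, the step of a number 49 percentage points lower from compound 1 to compound 4 (beyond the scatter) separates the effect of the amino on the carbonyl carbon, which the earlier comparison of the urea and amide had mixed with an aryl change. No measured evidence accounts for either step.

The compounds shown leave open whether a methyl, a methoxy or a nitrile on this aromatic carbon would give a similar read-out. They also leave open whether a longer chain in place of the amino would retain the effect.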